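Morpholine for thiomorpholine in a thiourea series

This account rests on a few compounds, and the source may have more. Where it says the series, first, only, none or still open, it means among the compounds named here.

Compounds measured in a functional assay on MCF7 cells (Homo sapiens) for cytotoxicity, read by MTT assay, with a stated time of 72 h; on this read-out higher numbers stand for weaker inhibition and lower numbers for stronger inhibition:
compound 1 `Cc1ccnc(/C(N)=N/NC(=S)N2CCOCC2)c1`, a limit of the assay, > 100000 nM
compound 2 `Cc1cccc(/C(N)=N/NC(=S)N2CCSCC2)n1`, a limit of the assay, > 100000 nM
compound 3 `Cc1ccnc(/C(N)=N/NC(=S)N2CCSCC2)c1`, 6900 nM

Compound 3 is the only one of the three with a number. From compound 3 to compound 1 the change is morpholin-4-yl in place of thiomorpholin-4-yl on a thiocarbonyl carbon, and the step is an at least 14-fold higher number from compound 3 to compound 1 (1.16 log units; beyond the scatter), reaching (the limit of > 100000 nM in this assay, at which 2 of the 3 values shown sit). Compound 2 and compound 3 have the same atoms joined differently; the difference between the two cores is not broken down here.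

Compound 4 `Cc1cccc(/C(N)=N/NC(=S)N2CCOCC2)n1` has not been measured in this assay. It differs from compound 2 by morpholin-4-yl in place of thiomorpholin-4-yl on a thiocarbonyl carbon, the same change as from compound 3 to compound 1. Since compound 2 already gives only a limit, compound 4 is expected to give a limit as well, an expected step that the limit leaves unreadable from compound 2 to compound 4 set beside an at least 14-fold higher number from compound 3 to compound 1 (1.16 log units; beyond the scatter). Compound 4 is therefore estimated at 250000 nM, between 100000 nM and 1000000 nM.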

Compound 4, half-maximal inhibitory concentration: 21500 nM
Beside the measured number, compound 4's estimate is 12-fold (1.07 log units) above it; the whole stated range lies above it.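

In this assay, morpholin-4-yl in place of thiomorpholin-4-yl on a thiocarbonyl carbon gives an at least 4.6-fold lower number from compound 2 to compound 4 (0.66 log units; beyond the scatter) on one core and an at least 14-fold higher number from compound 3 to compound 1 (1.16 log units; beyond the scatter) on the other. The change therefore does not carry over from one core to the other, even in direction: the same change on two cores in this assay, an at least 14-fold higher number (1.16 log units; beyond the scatter) from compound 3 to compound 1 and an at least 4.6-fold lower number (0.66 log units; beyond the scatter) from compound 2 to compound 4, at least 67-fold (1.82 log units) apart, beyond the scatter of two such steps

Each step has one end at a limit of the assay and gives only a minimum size, and the data do not show what in the two cores reverses the change. As far as these compounds go, it remains open whether other amines on the thiocarbonyl carbon, such as piperidine or dimethylamine, would split between the two cores in the same way. From the compounds shown here alone, it is also open whether a core carrying an ethyl or a methoxy group instead of the methyl would follow either result.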